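A few compounds are considered here, and "the series" means these few. Any claim that something is new, unique, unknown or untested is made for them only; others in the source may bear on it.

In an ADME assay on HepG2 cells (Homo sapiens) for cytotoxicity, read by luminescence, CellTiter-Glo and ATP content, with a stated time of 72 h (on this read-out higher numbers stand for an effect only at larger amounts of compound and lower numbers for an effect already at smaller amounts), compound 3 `COc1cccc(CNCCCNc2ccnc3cc(Oc4cccc(N(C)C)c4)ccc23)c1O` gives 7300 nM, the highest of the three numbers in hand. Compound 2 `COc1cccc(CNCCCNc2ccnc3cc(CCC(C)C)ccc23)c1O` gives 5390 nM, a number within the scatter of compound 3, while compound 1 `COc1ccc(F)cc1CNCCCNc1ccnc2cc(Cc3ccc(F)cc3Cl)ccc12` gives 2460 nM, a gap beyond the scatter. Compound 4 `COc1cccc(CNCCCNc2ccnc3cc(Cc4ccc(F)cc4Cl)ccc23)c1O` differs from compound 3 in one place: 2-chloro-4-fluorobenzyl in place of 3-(dimethylamino)phenoxy on an aromatic carbon. For the measured compounds named here, only one measured step bears on this position, a 1.4-fold higher number from compound 2 to compound 3 (0.13 log units; within the scatter), which exchanged a different group there without leaving the scatter. Compound 1 carries the same 2-chloro-4-fluorobenzyl group as compound 4 on a different left-hand part. The step to compound 4 is therefore expected to be a 1.8-fold lower number from compound 3 to compound 4 (0.26 log units; within the scatter), modest and toward lower numbers. Compound 4 is estimated at 4000 nM, with a range from 1500 nM to 9000 nM.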

Compound 4, half-maximal effective concentration: 2350 nM
Estimate against measurement, compound 4: 1.7-fold (0.23 log units) above; the range from low to high includes it.
By their numbers in this assay, from the lowest: compounds 4 and 1 (each within the scatter of the next); then compounds 2 and 3 (each within the scatter of the next).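

In this assay, this position can move the number after all: where the earlier exchange stayed within the scatter, 2-chloro-4-fluorobenzyl gives a 3.1-fold lower number from compound 3 to compound 4 (0.49 log units; beyond the scatter) and also a 2.3-fold lower number from compound 2 to compound 4 (0.36 log units; beyond the scatter). With this group in place, the change in the left-hand part gives a 1.0-fold lower number from compound 1 to compound 4 (0.02 log units; within the scatter), so the two left-hand parts do not separate. Nothing measured here explains these differences. Going by these compounds, it remains open whether an amine or a carboxylic acid at this position would shift the number, and whether the two left-hand parts would also match with isopentyl there.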